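The source may report more compounds than this note shows. Statements on the series, on what has been measured and on what is new or still open speak of the compounds shown alone.

Measured compounds:
compound 1, `COc1cc(C)cc(-c2c(-c3ccnc(-c4ccc(C(C)=O)cc4)c3)cnn2CC#N)c1`, 84%
compound 2, `COc1cc(C)cc(-c2nn(CC#N)cc2-c2ccnc(-c3ccc(N(C)C)cc3)c2)c1`, 97%

In a functional assay on A549 cells (Homo sapiens) for cytotoxicity, read by sulforhodamine B assay, with a stated time of 48 h, tested at 0.01 uM (on this read-out lower numbers stand for a stronger effect and higher numbers for a weaker effect at the one concentration tested), compound 1 gives 84%, the lowest of the two numbers recorded; the nearest value belongs to compound 2, which gives 97%, a reading higher by more than the usual scatter. Compound 3, `COc1cc(C)cc(-c2c(-c3ccnc(-c4ccc(N(C)C)cc4)c3)cnn2CC#N)c1`, has not yet been measured in this assay. It differs from compound 1 in one place: dimethylamino in place of acetyl on an aromatic carbon. For the measured compounds named here, the dimethylamino-bearing group that enters here also appears in compound 2, whose arrangement of the shared core otherwise differs from that of compound 3, so no direct step can be drawn between those two. Because compound 2 gives 97% with this same entering group, compound 3 is expected to read somewhat higher than compound 1, a step of a number 9 percentage points higher from compound 1 to compound 3 (within the scatter) that may sit at the edge of the scatter. Compound 3 is estimated at 93%, within a range from 80% to 102%.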

Compound 3, a percentage reported as activity, at one concentration (the size of the read-out at that concentration, not a potency): 59%
Beside the measured number, compound 3's estimate is 34 percentage points above it, and the stated range ends above it.
By their numbers in this assay, from the lowest: compound 3; then compound 1; then compound 2.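

In this assay, replacing acetyl with dimethylamino on the aromatic carbon para to a large group gives a number 25 percentage points lower from compound 1 to compound 3 (beyond the scatter), a change beyond the usual scatter. For the compounds shown here, the earlier compounds offered no step between compounds differing in one place, so this is the first sign that the reading responds to the group at this position, even though the two groups have the same heavy-atom count. Nothing available explains the size or direction of this step.

As far as these compounds go, it remains open how a primary amine, a methoxy group, a carboxylic acid or a bare hydrogen at this position would read alongside these two groups. From the compounds shown here alone, with a single step at a single concentration, it is also open whether the same exchange would give a similar step on a different arrangement of the core.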